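Adding a ring nitrogen to the indole of compound 1

A few compounds are considered here, and "the series" means these few. Any claim that something is new, unique, unknown or untested is made for them only; others in the source may bear on it.

Compound 1 `CN1CCN(c2ccc(Nc3cc(-c4c[nH]c5ccccc45)ncn3)cc2)CC1` has the higher of the two measured numbers: in an ADME assay on cells (Hepatocyte, Rattus norvegicus, strain Wistar Han) for metabolic stability (a lower number here means slower removal, a higher number faster removal of the compound), compound 1 gives 49 uL/min. In this assay compound 2 `COc1cc(N2CCN(C(C)=O)CC2)ccc1Nc1cc(-c2c[nH]c3cnccc23)ncn1` gives 9 uL/min, a gap beyond the scatter, though compound 2 differs from compound 1 in several places at once. Compound 3 `CN1CCN(c2ccc(Nc3cc(-c4c[nH]c5cnccc45)ncn3)cc2)CC1` alters compound 1 at one spot: a group of 9 heavy atoms (7 carbon, 2 nitrogen; one five-membered aromatic ring with 1 hetero atom, one six-membered aromatic ring with 1 hetero atom) in place of a group of 9 heavy atoms (8 carbon, 1 nitrogen; one five-membered aromatic ring with 1 hetero atom, one six-membered aromatic ring of carbon only), on an aromatic carbon. Going by the values given here, no measured pair isolates this change, so the direction is uncertain; because compound 2 gives 9 uL/min while carrying the same entering group, the step is expected to be a 2.0-fold lower number from compound 1 to compound 3 (0.29 log units; within the scatter), toward slower removal but smaller than that gap. Compound 3 is expected to give 25 uL/min, between 10 uL/min and 60 uL/min.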

Compound 3, intrinsic clearance in a liver preparation (reported as CLH), per the amount of preparation that the assay uses: 13 uL/min
Compound 3: middle estimate off by 1.9-fold (0.28 log units), on the high side; measured number inside the range.
By their numbers in this assay, from the lowest: compounds 2 and 3 (each within the scatter of the next); then compound 1.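

Going by these compounds alone, with only this one group changed, replacing 1H-indol-3-yl with its counterpart carrying a ring nitrogen gives a 3.8-fold lower number from compound 1 to compound 3 (0.58 log units; beyond the scatter) in this assay. The change alone therefore moves the compound toward slower removal, something the earlier comparison with compound 2 could not show, as that pair differs in several places at once. Nothing measured here explains this step. Going by these compounds, whether a fluorine or a nitrile in place of the added ring nitrogen would give a similar step remains open. So does whether this step would recur on a different core.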